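Compound 3 to compound 4: moving the methoxy

This account rests on a few compounds, and the source may have more. Where it says the series, first, only, none or still open, it means among the compounds named here.

In a functional assay on MDA-MB-231 cells (Homo sapiens) for inhibition, read by CCK-8 assay, with a stated time of 48 h (on this read-out higher numbers stand for weaker inhibition of growth and lower numbers for stronger inhibition of growth), compound 1 (`Cc1ccccc1Nc1nc(Nc2ccc(N3CCN(C)CC3)cn2)ncc1Cl`) gives 7470 nM, compound 2 (`COc1ccc(CNc2nc(Nc3ccc(N4CCN(C)CC4)cn3)ncc2Cl)cc1`) gives 14900 nM and compound 3 (`COc1cccc(CNc2nc(Nc3ccc(N4CCN(C)CC4)cn3)ncc2Cl)c1`) gives 20300 nM. Compound 3 cannot be separated from compound 2, but it does stand apart from compound 1, as a 2.7-fold higher number from compound 1 to compound 3 (0.43 log units; beyond the scatter) shows. That gap is modest, and the neighbouring a 2.0-fold higher number from compound 1 to compound 2 (0.30 log units; within the scatter) does not clear the scatter.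

Compound 4 (`COc1ccccc1CNc1nc(Nc2ccc(N3CCN(C)CC3)cn2)ncc1Cl`) has the same atoms as compound 3, joined differently: 2-methoxyphenyl in place of 3-methoxyphenyl on a saturated chain carbon bound to a nitrogen on an aromatic ring. The 2-methoxyphenyl group has not yet been measured on this chain carbon in any compound of the series.

For the measured compounds named here, the closest precedent is the one measured step that only shifts the methoxy group on that chain carbon: a 1.4-fold higher number from compound 2 to compound 3 (0.13 log units; within the scatter). The two steps from compound 1 replace the whole group and bear less directly on this change. On that single precedent, no step beyond the scatter is expected in this assay, and no direction can be read from the data. The expected step is a 1.3-fold lower number from compound 3 to compound 4 (0.10 log units; within the scatter). For compound 4 the estimated value is 16000 nM, with an expected range of 8000 nM to 32000 nM.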

Compound 4, concentration for 50% growth inhibition: 29300 nM
Compound 4: the middle estimate sits 1.8-fold (0.26 log units) below what was measured, within the range that was stated.
By their numbers in this assay, from the lowest: compounds 1, 2, 3 and 4 (each within the scatter of the next, the first and the last beyond it).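

With the 2-methoxyphenyl group on the saturated chain carbon, three methoxy placements can now be read side by side, and in this assay none of them separates from another: the change from 3-methoxyphenyl gives (a 1.4-fold higher number from compound 3 to compound 4 (0.16 log units; within the scatter)) and the change from 4-methoxyphenyl gives (a 2.0-fold higher number from compound 2 to compound 4 (0.29 log units; within the scatter)). The gap to the 2-methylphenyl group of compound 1 is clearer but still modest (a 3.9-fold higher number from compound 1 to compound 4 (0.59 log units; beyond the scatter)), which places compound 4 with compound 3 (a 2.7-fold higher number from compound 1 to compound 3 (0.43 log units; beyond the scatter)) beyond the scatter, while compound 2 goes against that reading (a 2.0-fold higher number from compound 1 to compound 2 (0.30 log units; within the scatter)). No outside measurement bears on these numbers.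

Open, as far as these compounds go, is whether a benzyl group with no methoxy, a 2-hydroxybenzyl group or a phenethyl chain on the same nitrogen would read any differently from the three methoxybenzyl compounds. The compounds shown also do not separate the effect of the benzyl chain carbon from that of the ring substituent in the steps from compound 1, a separation that a 2-methylbenzyl group or a 2-methoxyphenyl group directly on that nitrogen could provide.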